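The compounds below may be only part of what the source reports. "The series", "measured", "known", "first", "only" and "open" are said of these compounds alone.

Measured: compound 1 `CCc1nc(-c2ccc(C)cc2OC)c(CC)nc1NC(CC)CC`, 23.7 nM; compound 2 `CCc1nc(-c2ccc(OC(C)C)cc2OC)c(CC)nc1NC(CC)CC`, 4.2 nM.

For the measured compounds named here, in an assay on IMR-32 cells for displacement of a labelled ligand from corticotropin-releasing factor receptor 1 (Homo sapiens), read by scintillation counting, with a stated time of 2 h (on this read-out lower numbers stand for stronger inhibition and higher numbers for weaker inhibition), compound 2 gives the lowest of the two numbers; the only measured neighbour is compound 1, and the step of a 5.6-fold lower number from compound 1 to compound 2 (0.75 log units; beyond the scatter) lies beyond the scatter. Compound 3 `CCc1nc(-c2ccc(C(F)(F)F)cc2OC)c(CC)nc1NC(CC)CC` differs from compound 2 by trifluoromethyl in place of isopropoxy on an aromatic carbon. Going by the values given here, no measured step exchanges isopropoxy for trifluoromethyl; the step of a 5.6-fold lower number from compound 1 to compound 2 (0.75 log units; beyond the scatter) shows only that a change on this aromatic carbon moves the number, not in which direction a further change would. Compound 3 is therefore expected to land between the two measured numbers, a modest upward step a 2.9-fold higher number from compound 2 to compound 3 (0.46 log units; beyond the scatter). Estimated value for compound 3: 12 nM (range 4 nM to 35 nM).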

Compound 3, inhibition constant: 5.6 nM
Compound 3: the middle estimate sits 2.1-fold (0.33 log units) above what was measured; measured number inside the range.
By their numbers in this assay, from the lowest: compounds 2 and 3 (each within the scatter of the next); then compound 1.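

In this assay, the step of a 1.3-fold higher number from compound 2 to compound 3 (0.12 log units; within the scatter) does not separate trifluoromethyl from isopropoxy at this aromatic carbon, although only isopropoxy carries a hydrogen-bond acceptor. With a 4.2-fold lower number from compound 1 to compound 3 (0.63 log units; beyond the scatter), the lower number relative to methyl is no longer tied to isopropoxy alone, so an oxygen on this substituent is not required for it. No evidence on the cause of these steps is at hand. Open, from the compounds shown here alone, is how an amine, a carboxylic acid or a longer alkoxy chain would read at this carbon.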